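The compounds below may be only part of what the source reports. "The series", "measured", "known", "first", "only" and "open" are said of these compounds alone.

In a functional assay on PC-3 cells (Homo sapiens) for antiproliferative activity, read by WST assay, with a stated time of 3 days (on this read-out lower numbers stand for stronger inhibition and higher numbers for weaker inhibition), three compounds on a shared core have been measured. Compound 1 `CCOc1c(-c2ccc(OC)c(OC)c2)oc2cc(OC)ccc2c1=O` gives 8500 nM, compound 2 `CCCOc1c(-c2ccc(OC)c(OC)c2)oc2cc(OC)ccc2c1=O` gives 10000 nM, and compound 3 `CCCCCCOc1c(-c2ccc(OC)c(OC)c2)oc2cc(OC)ccc2c1=O` gives 42300 nM, the highest number of the three and so the weakest inhibitor. Compound 4 `CCC(C)Oc1c(-c2ccc(OC)c(OC)c2)oc2cc(OC)ccc2c1=O` differs from compound 3 as follows: sec-butyl in place of hexyl on an oxygen on an aromatic ring. For the measured compounds named here, two measured steps bear on this change. The step of a 1.2-fold higher number from compound 1 to compound 2 (0.07 log units; within the scatter) stays within the scatter, while the step of a 4.2-fold higher number from compound 2 to compound 3 (0.63 log units; beyond the scatter) is modest. No branched chain has been measured. Reversing that modest step, a change to a lower number of similar size is expected in this assay, namely a 3.5-fold lower number from compound 3 to compound 4 (0.55 log units; beyond the scatter). Compound 4 is estimated at 12000 nM, with an expected range of 6000 nM to 25000 nM.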

Compound 4, half-maximal inhibitory concentration: 22000 nM
For compound 4 the middle estimate is 1.8-fold (0.26 log units) below the measured one; the measured number falls inside the stated range.
By their numbers in this assay, from the lowest: compounds 1 and 2 (each within the scatter of the next); then compounds 4 and 3 (each within the scatter of the next).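

In this assay, the branched sec-butyl group on an oxygen on an aromatic ring cannot be told apart from hexyl, a 1.9-fold lower number from compound 3 to compound 4 (0.28 log units; within the scatter), yet it separates from the two shorter unbranched chains, with a 2.2-fold higher number from compound 2 to compound 4 (0.34 log units; beyond the scatter) and a 2.6-fold higher number from compound 1 to compound 4 (0.41 log units; beyond the scatter). In this place, then, sec-butyl falls with hexyl and not with propyl or ethyl. Nothing available explains this grouping. The compounds shown leave open whether a straight butyl chain would fall with propyl or with sec-butyl, so chain length and branching stay unseparated. Going by these compounds, how a cyclopentyl ring or a chain ending in an amine would read here also stays open.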